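Removing a methoxyethyl chain from two weak nicotinic antagonists

The compounds below may be only part of what the source reports. "The series", "measured", "known", "first", "only" and "open" are said of these compounds alone.

Measured compounds:
Compound 1, `COCCO[C@H]1CC[C@H]2CCN(C)[C@H]2C1`: in an assay on HEK293 cells for antagonist activity at Neuronal acetylcholine receptor; alpha3/beta4 (Rattus norvegicus), read by FLIPR, using a membrane potential dye (on this read-out higher numbers stand for weaker inhibition and lower numbers for stronger inhibition), compound 1 gives > 300000 nM, which is a limit of the assay and not a number.
Compound 2, `COCCO[C@H]1CC=C2CCN(C)[C@H]2C1`: in this assay compound 2 gives > 300000 nM, again only a limit.
Compound 3, `CN1CC[C@@H]2CC[C@H](O)C[C@@H]21`: in this assay compound 3 gives > 300000 nM, again only a limit.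

Compound 3 is made from compound 1 by one change, (hydrogen in place of 2-methoxyethyl on an oxygen on a saturated carbon). The step it produced, a step that the two limits leave unreadable from compound 1 to compound 3, cannot be sized, since both compounds stop at the same limit; the only common feature is the limit of > 300000 nM in this assay, at which 3 of the 3 values shown sit.

Compound 4, `CN1CCC2=CC[C@H](O)C[C@@H]21`, stands to compound 2 as compound 3 stands to compound 1: the change is hydrogen in place of 2-methoxyethyl on an oxygen on a saturated carbon, the same change at the same kind of place. The difference between the two cores, that of compound 1 and that of compound 2, is not broken down here.

Going by the values given here, for compound 4 in this assay a limit is expected rather than a number, because the limit of > 300000 nM in this assay, at which 3 of the 3 values shown sit, holds for every compound measured so far. The expected step that the limit leaves unreadable from compound 2 to compound 4 is therefore one of no readable movement. Compound 4 is estimated at 500000 nM, between 100000 nM and 3000000 nM.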

Compound 4, half-maximal inhibitory concentration: > 300000 nM
Compound 4 was reported as a limit; the forecaster's own chance of this, stated with the estimate: 90%; the middle value does not contradict the limit.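

Compound 2 and compound 4 both stop at the same limit rather than a number, so the step between them cannot be read, and neither can any other step here: the limit of > 300000 nM in this assay, at which 4 of the 4 values shown sit.

The compounds shown leave open whether changing 2-methoxyethoxy to hydroxy alters inhibition at all, on either core.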